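A Chlorophenyl Group Takes the Place of Phenethyl

The source may hold more compounds than are shown below. What is called first, only, known or untested is meant among the compounds shown, and "the series" means these compounds.

Of the compounds shown here, three built on one shared core have so far been tested in a functional assay on CCRF-CEM cells (Homo sapiens) for inhibition, read by cell counting, with a stated time of 3 days; a higher number here means a weaker inhibitor, a lower number a stronger inhibitor. Compound 1 `C=C(Br)C(=O)Nc1cccc(-c2cn3nc(-c4ccc(CC)cc4)sc3n2)c1` gives 3400 nM. Compound 2 `C=C(Br)C(=O)Nc1cccc(-c2cn3nc(-c4ccc(F)cc4)sc3n2)c1` gives 830 nM. Compound 3 `C=C(Br)C(=O)Nc1cccc(-c2cn3nc(CCc4ccccc4)sc3n2)c1` gives 4200 nM, the highest number of the three; its difference from compound 1 lies within the scatter, whereas the step of a 5.1-fold higher number from compound 2 to compound 3 (0.70 log units; beyond the scatter) lies beyond it.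

The next member is compound 4 `C=C(Br)C(=O)Nc1cccc(-c2cn3nc(-c4ccc(Cl)cc4)sc3n2)c1`, not yet measured. Its change from compound 3 is 4-chlorophenyl in place of phenethyl on an aromatic carbon. Two measured steps speak to this. The step of a 5.1-fold higher number from compound 2 to compound 3 (0.70 log units; beyond the scatter) shows that a halogen-bearing phenyl in this place gave a markedly lower number than the phenethyl chain, and the step of a 4.1-fold lower number from compound 1 to compound 2 (0.61 log units; beyond the scatter) shows that a fluoro group in this place did better than an ethyl group. The step of a 1.2-fold higher number from compound 1 to compound 3 (0.09 log units; within the scatter) adds only that 4-ethylphenyl and phenethyl sit within the scatter of each other. Since compound 4 carries a 4-chlorophenyl, closer in kind to the 4-fluorophenyl of compound 2 than to the phenethyl of compound 3, a modest move toward a lower number is expected, though not necessarily all the way to compound 2. Compound 4 is therefore estimated at about 1500 nM, with an expected range of 500 nM to 5000 nM. That expected change corresponds to a 2.8-fold lower number from compound 3 to compound 4 (0.45 log units; beyond the scatter).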

Compound 4, half-maximal inhibitory concentration: 3200 nM
Compound 4: the middle estimate sits 2.1-fold (0.33 log units) below what was measured, and the stated range covers the measured number.
By their numbers in this assay, from the lowest: compound 2; then compounds 4, 1 and 3 (each within the scatter of the next).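

In this assay the exchange of phenethyl for 4-chlorophenyl at this aromatic carbon gives a difference that cannot be told from scatter (a 1.3-fold lower number from compound 3 to compound 4 (0.12 log units; within the scatter)). Chloro likewise cannot be told from ethyl on the same phenyl ring (a 1.1-fold lower number from compound 1 to compound 4 (0.03 log units; within the scatter)), whereas it clearly parts from fluoro (a 3.9-fold higher number from compound 2 to compound 4 (0.59 log units; beyond the scatter)). The earlier compounds shown here left room for the reading that any halogen on this phenyl would go with a number as low as that of compound 2. Compound 4 goes against that reading: among these four, only the 4-fluorophenyl of compound 2 stands apart, and compounds 1, 3 and 4 all lie within the scatter of one another.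

On these data alone, whether a phenyl ring with no substituent, or one carrying a methoxy or a trifluoromethyl group in place of the chloro, would fall with compound 2 or with the other three remains open. Why fluoro and chloro part at this place also remains open, as nothing shown here bears on the cause.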